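Swapping trifluoromethyl for chloro on a pyrazole urea

A few compounds are considered here, and "the series" means these few. Any claim that something is new, unique, unknown or untested is made for them only; others in the source may bear on it.

Measured compounds:
Compound 1, `O=C(Nc1cccc(-n2cc(-c3ccncc3)c(-c3cc(O)cc(Cl)c3)n2)c1)Nc1ccc(Cl)c(C(F)(F)F)c1`: 84%
Compound 2, `O=C(Nc1cccc(-n2cc(-c3ccncc3)c(-c3cc(O)cc(Cl)c3)n2)c1)Nc1ccc(Cl)c(Cl)c1`: 71%
Compound 3, `COc1cc(Cl)cc(-c2nn(-c3cccc(NC(=O)Nc4ccc(Cl)c(C(F)(F)F)c4)c3)cc2-c2ccncc2)c1`: 74%

All three compounds were tested in a functional assay on 786-0 cells (Homo sapiens) for inhibition, read by sulforhodamine B assay, with a stated time of 48 h, tested at 1 uM; a lower number here means a stronger effect, a higher number a weaker effect of the compound at the concentration tested. Compound 1 gives 84% in this assay. Compound 2 differs from compound 1 by chloro in place of trifluoromethyl on an aromatic carbon, and that change made a step of a number 13 percentage points lower from compound 1 to compound 2 (beyond the scatter). Compound 3 differs from compound 1 by methyl in place of hydrogen on an oxygen on an aromatic ring, and the step there was a number 10 percentage points lower from compound 1 to compound 3 (within the scatter), so the numbers of compound 1 and compound 3 cannot be told apart. Within the data shown here, compound 2 and compound 3 also lie close together, with no step counted between them.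

Compound 4, `COc1cc(Cl)cc(-c2nn(-c3cccc(NC(=O)Nc4ccc(Cl)c(Cl)c4)c3)cc2-c2ccncc2)c1`, has not yet been measured. It differs from compound 3 by chloro in place of trifluoromethyl on an aromatic carbon. This is the same change that turned compound 1 into compound 2, and it sits in the same surroundings, so the step already seen offers the best guide. The cores of compound 3 and compound 4 carry the methyl on the oxygen that compound 1 lacks, the difference told above as methyl in place of hydrogen on an oxygen on an aromatic ring.

Compound 4 is therefore expected to give about 62% in this assay, somewhere between 50% and 74%. This expectation means a step of a number 12 percentage points lower from compound 3 to compound 4 (beyond the scatter), because the same change gave a number 13 percentage points lower from compound 1 to compound 2 (beyond the scatter) and the starting point of compound 3 is 74%. Among the measured compounds shown here, with only one earlier example of this change, the expected number is held loosely.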

Compound 4, a percentage reported as activity, at one concentration (the size of the read-out at that concentration, not a potency): 84%
Compound 4: the middle estimate sits 22 percentage points below what was measured, outside the stated range (above it).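

In this assay, the swap of trifluoromethyl for chloro gave a number 10 percentage points higher from compound 3 to compound 4 (within the scatter), so on the core that carries the methyl the two groups cannot be told apart, and the clear step seen on the core of compound 1 did not carry over: the same change on two cores in this assay, a number 13 percentage points lower (beyond the scatter) from compound 1 to compound 2 and a number 10 percentage points higher (within the scatter) from compound 3 to compound 4, 23 percentage points apart, beyond the scatter of two such steps The methyl on the oxygen shows the same dependence on its partner, giving a number 13 percentage points higher from compound 2 to compound 4 (beyond the scatter) when the 3,4-dichlorophenyl group is present, which does not match its step alongside the 4-chloro-3-(trifluoromethyl)phenyl group: the same change on two cores in this assay, a number 10 percentage points lower (within the scatter) from compound 1 to compound 3 and a number 13 percentage points higher (beyond the scatter) from compound 2 to compound 4, 23 percentage points apart, beyond the scatter of two such steps The effects of the two changes therefore do not simply add up in these four compounds, and a step measured on one core is a poor guide to the other, but four single readings at one concentration cannot show why the steps differ or whether the same holds elsewhere in the series.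

The compounds shown leave open how a fluoro or a methyl would read in place of the chloro or trifluoromethyl. They also leave open whether an ethyl or a longer chain on the oxygen would follow the pattern of compound 3 and compound 4, or that of compound 1 and compound 2.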